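Dropping the Chloro Group from Compound 2

The source may report more compounds than this note shows. Statements on the series, on what has been measured and on what is new or still open speak of the compounds shown alone.

Measured in a functional assay on A549 cells (Homo sapiens) for inhibition, read by CCK-8 assay, with a stated time of 72 h, tested at 10 uM; on this read-out higher numbers stand for more inhibition of growth at the one concentration tested and lower numbers for less inhibition of growth:
- compound 1 `COC(=O)c1ccc(NC(=O)C2(C(=O)Nc3ccc(Nc4ncc5cc(C(=O)N(C)C)n(C6CCCC6)c5n4)cc3)CC2)cc1` gives 92%
- compound 2 `CN(C)C(=O)c1cc2cnc(Nc3ccc(NC(=O)C4(C(=O)Nc5cccc(Cl)c5)CC4)cc3)nc2n1C1CCCC1` gives 90.7%
- compound 3 `CN(C)C(=O)c1cc2cnc(Nc3ccc(NC(=O)C4(C(=O)Nc5ccc(O)cc5)CC4)cc3)nc2n1C1CCCC1` gives 94.4%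

Compound 2 holds the lowest of the three numbers, yet its gaps to compound 1 and to compound 3 both fall within the scatter. The unmeasured compound 4 `CN(C)C(=O)c1cc2cnc(Nc3ccc(NC(=O)C4(C(=O)Nc5ccccc5)CC4)cc3)nc2n1C1CCCC1` differs from compound 2 by hydrogen in place of chloro on an aromatic carbon, the cut one bond further out reading 3-chlorophenyl to phenyl on the amide-type nitrogen. Among the compounds with values here, the steps that bear on this swap at the same position are a number 1.3 percentage points lower from compound 1 to compound 2 (within the scatter) and a number 3.7 percentage points higher from compound 2 to compound 3 (within the scatter), each within the scatter, so no step beyond the scatter is expected in this assay. Compound 4 is therefore estimated at 90%, ranging from 80% to 97%, which means an expected step of a number 0.7 percentage points lower from compound 2 to compound 4 (within the scatter).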

Compound 4, percent growth inhibition at one concentration: 88.8%
Compound 4: the middle estimate sits 1.2 percentage points above what was measured, within the range that was stated.
By their numbers in this assay, from the lowest: compounds 4, 2, 1 and 3 (each within the scatter of the next).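

In this assay, the unsubstituted phenyl of compound 4 shows that this ring needs no substituent to keep its reading: taking off the chloro stays within the scatter (a number 1.9 percentage points lower from compound 2 to compound 4 (within the scatter)). The comparisons with the other two substituents read the same way (a number 5.6 percentage points lower from compound 3 to compound 4 (within the scatter); a number 3.2 percentage points lower from compound 1 to compound 4 (within the scatter)), so hydrogen, chloro, hydroxy and methoxycarbonyl on this ring cannot be told apart at this single concentration. Nothing at hand explains this flat result. On these data alone, whether an amine or a carboxylic acid on this ring would keep the reading stays open, as does whether these four compounds would separate at lower concentrations.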